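Stability of Two Ester Pairs in Phosphate Buffer

The source may hold more compounds than are shown below. What is called first, only, known or untested is meant among the compounds shown, and "the series" means these compounds.

Compound 1 `CC(C)OC(=O)c1cccc(NC(=O)[C@@H]2C[C@H](SC3=C(C(=O)O)N4C(=O)[C@H]([C@@H](C)O)[C@H]4[C@H]3C)CN2)c1` gives > 95%, a limit of the assay.
Compound 2 `CC(C)C(=O)OCOC(=O)c1cccc(NC(=O)[C@@H]2C[C@H](SC3=C(C(=O)O)N4C(=O)[C@H]([C@@H](C)O)[C@H]4[C@H]3C)CN2)c1` gives > 95%, a limit of the assay.
Compound 3 `CC(C)OC(=O)C1=C(S[C@@H]2CN[C@H](C(=O)Nc3cccc(C(=O)O)c3)C2)[C@H](C)[C@@H]2[C@@H]([C@@H](C)O)C(=O)N12` gives > 95%, a limit of the assay.

All three measured compounds were tested in a physicochemical assay for metabolic stability, read by LC-MS, in phosphate buffer, with a stated time of 3 h, at pH 7.4, tested at 50 uM; a higher number here means that more of the compound is left, a lower number that less of the compound is left. Compound 1 and compound 2 differ in one place, (((isopropylcarbonyl)oxy)methyl in place of isopropyl on an oxygen next to a carbonyl group), and the step between them reads a step that the two limits leave unreadable from compound 1 to compound 2. The cores of compound 1 and compound 3 are built from the same atoms joined differently; the difference between the two cores is not broken down here. Across the set, (the limit of > 95% in this assay, at which 3 of the 3 values shown sit), so no measured step can be sized.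

Compound 4 `CC(C)C(=O)OCOC(=O)C1=C(S[C@@H]2CN[C@H](C(=O)Nc3cccc(C(=O)O)c3)C2)[C@H](C)[C@@H]2[C@@H]([C@@H](C)O)C(=O)N12` is not yet measured. It differs from compound 3 by ((isopropylcarbonyl)oxy)methyl in place of isopropyl on an oxygen next to a carbonyl group, the same change that turns compound 1 into compound 2, at a place described in the same words. Since the step from compound 1 to compound 2 sits at the limit on both ends, the step from compound 3 to compound 4 in this assay is expected to be a step that the limit leaves unreadable from compound 3 to compound 4. Compound 4 is therefore estimated at 96%, with a range of 88% to 100%.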

Compound 4, percent of the compound remaining: > 95%
Compound 4: a limit, no number; the forecaster's own chance of this, stated with the estimate: 80%; the middle value is on the limit's open side.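

In this assay compound 4 gives > 95%, which is a limit of the assay and not a number. The step between compound 3 and compound 4 therefore cannot be read: the limit of > 95% in this assay, at which 4 of the 4 values shown sit. The compounds shown leave open whether isopropyl and ((isopropylcarbonyl)oxy)methyl differ at all in this assay, in either pair.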